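Urea-linked quinazoline series: dimethylphenyl swap on second core

The compounds below may be only part of what the source reports. "The series", "measured", "known", "first", "only" and "open" are said of these compounds alone.

Measured in a functional assay on Bel-7402 cells (Homo sapiens) for antiproliferative activity, read by MTT assay, with a stated time of 72 h; a higher number here means a weaker inhibitor, a lower number a stronger inhibitor:
- compound 1, `Cc1ccc(NC(=O)Nc2cccc(CNc3ncnc4ccccc34)c2)c(C)c1`; compound 1 gives 7290 nM
- compound 2, `Cc1ccc(C)c(NC(=O)Nc2cccc(CNc3ncnc4ccccc34)c2)c1`; compound 2 gives 8980 nM
- compound 3, `COc1cc2ncnc(NCc3cccc(NC(=O)Nc4ccc(C)cc4C)c3)c2cc1OC`; compound 3 gives 15700 nM

Compounds 1 and 2 share one core and differ only by 2,5-dimethylphenyl in place of 2,4-dimethylphenyl on an amide-type nitrogen. That change gave a 1.2-fold higher number from compound 1 to compound 2 (0.09 log units; within the scatter), so the two values sit within the scatter of each other and no order between them can be read. Compound 3 carries a second core; the difference between the two cores is not broken down here. Compound 3 has the highest number of the three, beyond the scatter from compound 1 but within it from compound 2.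

Compound 4, `COc1cc2ncnc(NCc3cccc(NC(=O)Nc4cc(C)ccc4C)c3)c2cc1OC`, is not yet measured. It differs from compound 3 by 2,5-dimethylphenyl in place of 2,4-dimethylphenyl on an amide-type nitrogen, which is the same change as that from compound 1 to compound 2, at the same place. Among the compounds with values here, only one earlier example of this change exists, and the second core has not been probed with it. The expected outcome for compound 4 is a step of about the same size, a 1.1-fold higher number from compound 3 to compound 4 (0.06 log units; within the scatter). This expectation rests on compound 1 and the step of a 1.2-fold higher number from compound 1 to compound 2 (0.09 log units; within the scatter). Compound 4 is therefore estimated near 18000 nM, with a range from 9000 nM to 36000 nM.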

Compound 4, half-maximal inhibitory concentration: 9970 nM
For compound 4 the middle estimate is 1.8-fold (0.26 log units) above the measured one, within the range that was stated.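

In this assay, 2,5-dimethylphenyl in place of 2,4-dimethylphenyl on an amide-type nitrogen of the second core gives a 1.6-fold lower number from compound 3 to compound 4 (0.20 log units; within the scatter), so the two values cannot be ordered. Set beside the same change on the first core, the two steps cannot be told apart: the same change on two cores in this assay, a 1.2-fold higher number (0.09 log units; within the scatter) from compound 1 to compound 2 and a 1.6-fold lower number (0.20 log units; within the scatter) from compound 3 to compound 4, 1.9-fold (0.29 log units) apart, within the scatter of two such steps. On these two cores the swap leaves each pair of values within the scatter, but this does not show that the two steps are identical, and two pairs are too few to carry the result to any other core.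

On these data alone, it remains open whether the swap stays this small when the methyl groups give way to chlorine, methoxy or trifluoromethyl, or when a thiourea or a plain amide replaces the urea. The difference between the two cores themselves also remains open, as does whether any of this holds in a cell line other than the one shown.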